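A few compounds are considered here, and "the series" means these few. Any claim that something is new, unique, unknown or untested is made for them only; others in the source may bear on it.

Compound 1 `CCCCCCNC(=O)c1cc(C#Cc2cc(OC)ccc2OC)ccc1OC` offers no number to start from. In a functional assay on SF-539 cells (Homo sapiens) for antiproliferative activity (on this read-out higher numbers stand for weaker inhibition of growth and lower numbers for stronger inhibition of growth), compound 1 gives > 100000 nM, which is a limit of the assay and not a measured value. Compound 2 `COC(=O)c1cc(/C=C\c2cc(OC)ccc2OC)ccc1OC` does return a number, and in this assay compound 2 gives 10600 nM. The next compound to be tested is compound 3 `COC(=O)c1cc(C#Cc2cc(OC)ccc2OC)ccc1OC`, which keeps the core of compound 1 and alters one group: methoxy in place of hexylamino on a carbonyl carbon. For the measured compounds named here, no measured pair isolates this change, so any expectation rests on indirect evidence. Compound 2 also carries methoxy on a carbonyl carbon, and with compound 2 at 10600 nM a measurable value seems likely for compound 3, although the two structures differ elsewhere. The expected movement is therefore towards stronger inhibition of growth, with an estimated step of an at least 12-fold lower number from compound 1 to compound 3 (1.09 log units; beyond the scatter), whose true size stays uncertain since its starting point is only a limit. For compound 3 the estimated value in this assay is 8000 nM, with an expected range from 1500 nM to 50000 nM.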

Compound 3, concentration for 50% growth inhibition: 81100 nM
Beside the measured number, compound 3's estimate is 10-fold (1.01 log units) below it, outside the stated range (above it).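

In this assay compound 3 gives 81100 nM, which shows that with methoxy in place of hexylamino on this carbonyl carbon, the shared core returns a measured value. The step is an at least 1.2-fold lower number from compound 1 to compound 3 (0.09 log units; that floor lies within the scatter), so the change can be read only as a floor, and that floor does not separate the two compounds beyond the usual scatter. Its true size stays unknown because compound 1 has only a limit of the assay to offer, not a number: the limit of > 100000 nM in this assay, at which 1 of the 3 values shown sits.

The compounds shown leave open whether a shorter chain such as methylamino or butylamino, a free carboxylic acid or a plain amine on the same carbonyl carbon would give a measurable value, and so whether the length of the hexyl chain or the amide itself sets the result for compound 1. As far as these compounds go, it also stays open how hexylamino would read on the core of compound 2, which carries methoxy at this place.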